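The source may hold more compounds than are shown below. What is called first, only, known or untested is meant among the compounds shown, and "the series" means these compounds.

The study works from a shared core, seen in compound 1 `O=C(O)CCc1cccc2c1B(O)OC2`. In a functional assay on HCT-116 cells (Homo sapiens) for antiproliferative activity, read by MTT assay, with a stated time of 72 h (on this read-out higher numbers stand for weaker inhibition and lower numbers for stronger inhibition), compound 1 gives only a limit, > 100000 nM. Compound 2 `O=C(CCc1cccc2c1B(O)OC2)Nc1nccs1` carries (1,3-thiazol-2-yl)amino in place of hydroxy on a carbonyl carbon. In this assay compound 2 likewise gives only a limit, > 100000 nM. The step that the two limits leave unreadable from compound 1 to compound 2 therefore cannot be read in size, since (the limit of > 100000 nM in this assay, at which 2 of the 2 values shown sit). On the numbers shown, compound 2 stands at the limit, with nothing to set it apart from compound 1.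

The compound not yet measured is compound 3 `O=C(CCc1cccc2c1B(O)OC2)Nc1ccc(I)cc1`. The change is 4-iodophenyl in place of 1,3-thiazol-2-yl on an amide-type nitrogen. Among the compounds with values here, the only measured step, a step that the two limits leave unreadable from compound 1 to compound 2, is the sole point of comparison, and its size is unreadable, so no direction can be drawn from it for this assay. With both measured compounds sitting at the limit, the expected step that the limit leaves unreadable from compound 2 to compound 3 is one that cannot be placed beyond the scatter. Compound 3 is therefore estimated at 150000 nM, within a range from 30000 nM to 500000 nM, most probably reported once more as a limit.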

Compound 3, half-maximal inhibitory concentration: 50000 nM
Estimate against measurement, compound 3: 3.0-fold (0.48 log units) above; the measured number falls inside the stated range.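

Compound 3 is the first of the compounds shown to give a number rather than a limit in this assay, so the amide-type nitrogen is a place where a change of group can bring the reading inside the range of the assay. Setting 4-iodophenyl in place of 1,3-thiazol-2-yl there gives an at least 2.0-fold lower number from compound 2 to compound 3 (0.30 log units; that floor lies within the scatter), which fixes a floor for the step but not its full size, and that floor alone does not carry the step beyond the usual scatter. The step can be given only as a floor because compound 2 rests on a limit: the limit of > 100000 nM in this assay, at which 2 of the 3 values shown sit.

From the compounds shown here alone, whether a plain phenyl or a 4-chlorophenyl on the same nitrogen would read like compound 3 stays open, so the iodine cannot yet be separated from the ring that carries it. Also open, going by these compounds, is how a longer chain joining the shared core to the amide carbonyl would read in this assay, and so whether the chain has any part in the reading of compound 3.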